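The source may report more compounds than this note shows. Statements on the series, on what has been measured and on what is new or still open speak of the compounds shown alone.

Measured so far in an ADME assay on J774.1 cells (Mus musculus) for cytotoxicity, with a stated time of 48 h; a lower number here means that less compound is needed, a higher number that more compound is needed for the effect:
- compound 1, `COC(=O)C1=C(O)C[C@H](c2ccccn2)N(Cc2ccc(OC)cc2)[C@@H]1c1ccccn1`: 29.9 uM
- compound 2, `COC(=O)C1C(=O)C(C(=O)OC)[C@H](c2ccccn2)N(CCCC(=O)O)[C@@H]1c1ccccn1`: 46 uM
- compound 3, `C=CCN1[C@H](c2ccccn2)C(C(=O)OC)C(=O)C(C(=O)OC)[C@@H]1c1ccccn1`: a limit of the assay, > 100 uM

Compound 1 stands at the lowest of the two numbers in this assay. Its nearest neighbour is compound 2 with 46 uM; the gap between compound 1 and compound 2 lies within the scatter, so the two are not told apart. For compound 3 only the limit > 100 uM is known.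

Among the compounds with values here, the single measured step, an at least 2.1-fold higher number from compound 2 to compound 3 (0.33 log units; beyond the scatter), concerns the chain on the ring nitrogen and involves the limit noted in the limit of > 100 uM in this assay, at which 1 of the 3 values shown sits; it does not touch the benzyl ring and so does not bear on the change studied here.

Compound 4, `COC(=O)C1=C(O)C[C@H](c2ccccn2)N(Cc2ccc(C)cc2)[C@@H]1c1ccccn1`, differs from compound 1 only by methyl in place of methoxy on an aromatic carbon. Within the data shown here, no measured pair carries this change, so there is no step from which to read its size. With nothing pointing either way, the expected step is a 1.1-fold higher number from compound 1 to compound 4 (0.04 log units; within the scatter), that is, none beyond the scatter. Compound 4 is therefore estimated at 33 uM in this assay, with a range from 14 uM to 80 uM.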

Compound 4, concentration for half-maximal effect: 34.9 uM
Estimate against measurement, compound 4: 1.1-fold (0.02 log units) below; the range from low to high includes it.
By their numbers in this assay, from the lowest: compounds 1, 4 and 2 (each within the scatter of the next). At a limit, above all of these: compound 3.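

In this assay, within the data shown here, the first direct reading at this place on the benzyl ring is a 1.2-fold higher number from compound 1 to compound 4 (0.07 log units; within the scatter), so 4-methoxybenzyl and 4-methylbenzyl on the ring nitrogen are not told apart. The change removes the oxygen and the one hydrogen-bond acceptor counted for methoxy, and within this pair the reading does not follow that loss beyond the scatter. No measurement shown bears on why this step is so small.

Open, from the compounds shown here alone, is whether another group at this place on the aromatic ring, such as an amine, a carboxylic acid or a nitrile, would give a step beyond the scatter, and whether a longer chain such as ethoxy in place of methoxy would stay as close to compound 1 and compound 4 as these two stand to each other. Also open, going by these compounds, is whether the same change would give so small a step on the core carried by compound 2 and compound 3, since this single pair speaks only for the core of compound 1.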